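This account rests on a few compounds, and the source may have more. Where it says the series, first, only, none or still open, it means among the compounds named here.

Series notes. Compound 1 `COc1ccccc1-c1nnc(-c2ccc(C(=O)N/N=C/c3cccc(F)c3)cc2)o1` carries a 3-fluorophenyl on a carbon with a double bond to nitrogen; in an ADME assay on THP-1 cells (Homo sapiens) for cytotoxicity (on this read-out higher numbers stand for weaker inhibition and lower numbers for stronger inhibition), compound 1 gives 353000 nM, the second highest of the three numbers measured. Compound 2 `COc1ccccc1-c1nnc(-c2ccc(C(=O)N/N=C/c3ccc(F)cc3)cc2)o1` gives 427000 nM and compound 3 `COc1ccccc1-c1nnc(-c2ccc(C(=O)N/N=C/c3ccncc3)cc2)o1` gives 173000 nM. The step of a 1.2-fold higher number from compound 1 to compound 2 (0.08 log units; within the scatter) lies within the scatter, whereas a 2.0-fold lower number from compound 1 to compound 3 (0.31 log units; beyond the scatter) and a 2.5-fold lower number from compound 2 to compound 3 (0.39 log units; beyond the scatter) are modest steps beyond it. Compound 4 `COc1ccc(O)c(/C=N/NC(=O)c2ccc(-c3nnc(-c4ccccc4OC)o3)cc2)c1` differs from compound 1 by 2-hydroxy-5-methoxyphenyl in place of 3-fluorophenyl on a carbon with a double bond to nitrogen. Among the compounds with values here, no measured step introduces a hydroxyl or methoxy group at this place; the only steps beyond the scatter concern pyridin-4-yl, so none bears directly. The step is therefore expected to stay within the scatter or be at most modest, in either direction, a 1.2-fold lower number from compound 1 to compound 4 (0.07 log units; within the scatter). Compound 4 is expected to give about 300000 nM, between 120000 nM and 750000 nM.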

Compound 4, half-maximal inhibitory concentration: 303000 nM
The estimate for compound 4 lay 1.0-fold (0.00 log units) below the measured number, within the range that was stated.
By their numbers in this assay, from the lowest: compounds 3, 4, 1 and 2 (each within the scatter of the next, the first and the last beyond it).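

In this assay, 2-hydroxy-5-methoxyphenyl, which brings a hydrogen-bond donor and acceptors that the fluorophenyl groups lack, leaves the number little changed: a 1.2-fold lower number from compound 1 to compound 4 (0.07 log units; within the scatter) and a 1.4-fold lower number from compound 2 to compound 4 (0.15 log units; within the scatter) both stay within the scatter. Against pyridin-4-yl, a 1.8-fold higher number from compound 3 to compound 4 (0.24 log units; within the scatter) also stays within it, so compound 4 cannot be separated from any of the other three, although compound 2 and compound 3 remain apart. No evidence is at hand on the origin of these numbers.

As far as these compounds go, whether an amine or a carboxylic acid on this carbon with a double bond to nitrogen would move the number beyond the scatter stays open. Also open, from the compounds shown here alone, is what the hydroxyl or the methoxy does alone.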